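Isobutoxy for cyclohexyl on the carbonyl carbon

This account rests on a few compounds, and the source may have more. Where it says the series, first, only, none or still open, it means among the compounds named here.

Measured so far in a functional assay on BeWo cells (Homo sapiens) for inhibition, read by MTT assay, with a stated time of 72 h; a lower number here means a stronger inhibitor, a higher number a weaker inhibitor
- compound 1 `CN(C)c1nnc2nncn2n1` gives 610 nM
- compound 2 `O=C(C1CCCCC1)N1CCN(c2nnc3nncn3n2)CC1` gives 1900 nM

Compound 2 (1900 nM) has the higher number of the two and so is the weaker inhibitor, and its gap to compound 1 (610 nM) lies beyond the scatter. Compound 3 (`CC(C)COC(=O)N1CCN(c2nnc3nncn3n2)CC1`) keeps the shared core and carries isobutoxy in place of cyclohexyl on a carbonyl carbon. For the measured compounds named here, no measured pair shows this change, so the expectation rests on the value of compound 2 (1900 nM) alone. A small move toward a lower number is expected, with the estimated step (a 1.3-fold lower number from compound 2 to compound 3 (0.10 log units; within the scatter)) staying within the scatter. In this assay the estimate for compound 3 is 1500 nM (expected range 550 nM to 4500 nM).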

Compound 3, half-maximal inhibitory concentration: 13100 nM
Compound 3: middle estimate off by 8.7-fold (0.94 log units), on the low side; measured number outside the range, above it.
By their numbers in this assay, from the lowest: compound 1; then compound 2; then compound 3.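

In this assay, the group on the carbonyl carbon matters: isobutoxy in place of cyclohexyl gives a 6.9-fold higher number from compound 2 to compound 3 (0.84 log units; beyond the scatter), so compound 3 is the weaker inhibitor of this pair and the two groups are not interchangeable at this place. The change replaces a carbon-only six-membered non-aromatic ring with an open group that brings oxygen and a hydrogen-bond acceptor, so the ring and the oxygen both change in one step. No available measurement bears on the reason for this step.

The contribution of each part of the change remains unresolved, as the ring and the oxygen are not varied separately in the compounds shown. Isobutyl on the carbonyl carbon would hold the open carbon chain without the oxygen, and cyclohexyloxy would hold the ring with the oxygen, which would separate the two.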